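The source may report more compounds than this note shows. Statements on the series, on what has been measured and on what is new or still open speak of the compounds shown alone.

Measured compounds:
- compound 1, `CCOC1=CC(=O)c2ccccc2C1=O`: 16900 nM
- compound 2, `C=CCOc1ccc2c(c1)C(=O)C=CC2=O`: 10200 nM
- compound 3, `O=C1C=CC(=O)c2cc(OCc3ccccc3)ccc21`: 26200 nM

In a functional assay on KB cells (Homo sapiens) for cytotoxicity (on this read-out lower numbers stand for stronger inhibition and higher numbers for weaker inhibition), compound 1 gives 16900 nM, the second highest of the three numbers; its gaps to compound 3 and to compound 2 both lie within the scatter, so no order among them can be read. Compound 4, `CCCOC1=CC(=O)c2ccccc2C1=O`, differs from compound 1 by methyl in place of hydrogen on a saturated chain carbon, two bonds along the chain from an oxygen on an unsaturated carbon. Among the measured compounds shown here, the only step in hand, a 2.6-fold higher number from compound 2 to compound 3 (0.41 log units; beyond the scatter), concerns a different change and does not speak to a longer chain at this position, so there is no direct guide. Without such a guide, compound 4 is expected to stay close to compound 1, with a step of a 1.2-fold lower number from compound 1 to compound 4 (0.08 log units; within the scatter) that sits within the scatter. Compound 4 is estimated at 14000 nM, in the range 6000 nM to 35000 nM.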

Compound 4, half-maximal inhibitory concentration: 49400 nM
Estimate against measurement, compound 4: 3.5-fold (0.55 log units) below; the whole stated range lies below it.
By their numbers in this assay, from the lowest: compounds 2, 1, 3 and 4 (each within the scatter of the next, the first and the last beyond it).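

In this assay, going from ethoxy to propoxy gives a 2.9-fold higher number from compound 1 to compound 4 (0.47 log units; beyond the scatter), so inhibition becomes weaker. The earlier compounds shown here did not test this chain, and this step shows that even a single added methyl at this position can shift the read-out beyond the scatter. Nothing available explains this shift. A single step cannot establish a trend with chain length. On these data alone, whether a longer chain such as butoxy would weaken inhibition further, or whether an amine at the chain end would reverse the loss, remains open.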